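Working notes: from compound 3 to compound 4

A few compounds are considered here, and "the series" means these few. Any claim that something is new, unique, unknown or untested is made for them only; others in the source may bear on it.

compound 1 `O=C(/C=C/c1cccnc1)NCCCc1ccc(S(=O)(=O)Nc2ccccc2)cc1` gives > 10000 nM (a limit of the assay)
compound 2 `O=C(/C=C/c1cccnc1)NCCCCCCCc1ccc(S(=O)(=O)Nc2ccccc2)cc1` gives 223 nM (a number)
compound 3 `O=C(/C=C/c1cccnc1)NCCCCCCc1cccc(S(=O)(=O)Nc2ccccc2)c1` gives 30.4 nM (a number)

All three readings come from a functional assay on HeLa cells (Homo sapiens) for inhibition, read by CCK-8 assay, with a stated time of 72 h (on this read-out lower numbers stand for stronger inhibition and higher numbers for weaker inhibition), in this series. Of the two numbers, compound 3 stands lowest, and compound 2 lies higher, beyond the scatter. Compound 4 `CCc1ccc(NS(=O)(=O)c2cccc(CCCCCCNC(=O)/C=C/c3cccnc3)c2)cc1` differs from compound 3 by ethyl in place of hydrogen on an aromatic carbon and nothing else. For the measured compounds named here, no measured pair shows this change, so the expectation starts from compound 3 at 30.4 nM and holds no shift beyond the scatter in this assay, in either direction. The estimated change is a 1.0-fold lower number from compound 3 to compound 4 (0.01 log units; within the scatter) (an expectation only). Compound 4 is expected at an estimated 30 nM (range 7 nM to 130 nM).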

Compound 4, half-maximal inhibitory concentration: 132 nM
Estimate against measurement, compound 4: 4.4-fold (0.64 log units) below; measured number outside the range, above it.
By their numbers in this assay, from the lowest: compound 3; then compounds 4 and 2 (each within the scatter of the next). At a limit, above all of these: compound 1.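

Compound 4 is the first compound shown with a group on the anilino ring, and in this assay 4-ethylphenyl in place of phenyl gives a 4.3-fold higher number from compound 3 to compound 4 (0.64 log units; beyond the scatter) so this position is not indifferent to substitution. For the compounds shown here, one step, however, gives only this one reading of the position. No measured property shown bears on this step.

As far as these compounds go, whether the higher number is specific to ethyl or would also follow from another group remains open. A methyl, a fluorine, a methoxy or a carboxylic acid at this position could separate these cases.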